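Bromo in Place of Hydrogen on Compound 2

The compounds below may be only part of what the source reports. "The series", "measured", "known", "first", "only" and "open" are said of these compounds alone.

Compound 1: `CCCCCCCCCCCCCCC(=O)Oc1ccc(COP(=O)(OCc2ccc(OC(=O)CCCC)cc2)OP(=O)(O)OP(=O)(O)OC[C@H]2O[C@@H](n3ccnc(C(N)=O)c3=O)[C@H](O)[C@@H]2O)cc1`, 16000 nM
Compound 2: `NC(=O)c1nccnc1O`, only a limit, > 250000 nM
Compound 3: `NC(=O)c1nc(Br)cn([C@@H]2O[C@H](CO)[C@@H](O)[C@H]2O)c1=O`, only a limit, > 250000 nM

Among the measured compounds shown here, in an ADME assay on MDCK cells (Canis lupus familiaris) for cytotoxicity, read by microscopy, with a stated time of 3 days (on this read-out higher numbers stand for lower toxicity in this test and lower numbers for higher toxicity in this test), compound 1 gives 16000 nM, the one number among the three. Compound 2 reaches only a limit of the assay there, > 250000 nM. Compound 3 likewise reaches only a limit, > 250000 nM. Compound 2 therefore stands at the limit of > 250000 nM in this assay, at which 2 of the 3 values shown sit, with no number of its own to compare against compound 1.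

Compound 4, `NC(=O)c1nc(Br)cnc1O`, differs from compound 2 by bromo in place of hydrogen on an aromatic carbon. For the measured compounds named here, no pair of the measured compounds differs in a single place, so no measured step in this assay can be carried over to this change. What can be said is that compound 3 also carries a bromo on its ring and sits at the same limit as compound 2, while compound 1 carries no bromo and gives a number.

On this footing the expected step of a number no higher from compound 2 to compound 4 (the limit leaves the size open) is none beyond the usual scatter. Compound 4 is expected to come out at 250000 nM, within 120000 nM to 500000 nM, most probably again as a limit rather than a number.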

Compound 4, minimum cytotoxic concentration: > 250000 nM
Compound 4: a limit, no number (the forecaster's own chance of this, stated with the estimate: 75%); the middle value lies on the limit itself.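

In this assay compound 2 and compound 4 each give only a limit and no number, so no step can be read from one to the other: the limit of > 250000 nM in this assay, at which 3 of the 4 values shown sit. The compounds shown leave open whether bromo in place of hydrogen on an aromatic carbon changes the minimum cytotoxic concentration at all, and by how much.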